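Cyclohexenyl in Place of the Benzoyl Phenyl

The source may report more compounds than this note shows. Statements on the series, on what has been measured and on what is new or still open speak of the compounds shown alone.

In an assay on HEK293 cells for displacement of a labelled ligand from metabotropic glutamate receptor 5 (Rattus norvegicus) (on this read-out higher numbers stand for weaker inhibition and lower numbers for stronger inhibition), compound 1 `O=C(Nc1cc(-c2ccccc2)nn1-c1ccccc1)c1ccccc1` gives 4180 nM, the highest of the two numbers measured. Compound 2 `O=C(Nc1cc(-c2ccccc2)nn1-c1ccccc1F)c1ccccc1` gives 2700 nM; the step is a 1.5-fold lower number from compound 1 to compound 2 (0.19 log units; within the scatter). Compound 3 `N#Cc1cccc(-n2nc(-c3ccccc3)cc2NC(=O)c2ccccc2)c1` reaches only the assay limit of > 10000 nM. The step from compound 1 to compound 4 `O=C(Nc1cc(-c2ccccc2)nn1-c1ccccc1)C1=CCCCC1` is a different kind of change: cyclohex-1-en-1-yl in place of phenyl on a carbonyl carbon. Within the data shown here, none of the measured steps touches the carbonyl side; all three vary the group on the aromatic nitrogen, so they offer no direct guide to this change. Compound 4 is therefore expected to stay close to compound 1, with at most a modest shift, a 1.4-fold higher number from compound 1 to compound 4 (0.16 log units; within the scatter). The estimate for compound 4 is 6000 nM, within 2500 nM to 15000 nM.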

Compound 4, inhibition constant: 4470 nM
Estimate against measurement, compound 4: 1.3-fold (0.13 log units) above; measured number inside the range.
By their numbers in this assay, from the lowest: compounds 2, 1 and 4 (each within the scatter of the next). At a limit, above all of these: compound 3.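

This is the only step shown on the carbonyl side, and in this assay it is a 1.1-fold higher number from compound 1 to compound 4 (0.03 log units; within the scatter). On this carbonyl carbon, an aromatic ring of carbon only can thus give way to the non-aromatic cyclohex-1-en-1-yl ring with no readable change in the number. Nothing measured here gives a reason for this result.

Still open, going by these compounds, is how this carbonyl carbon responds to an amine, a carboxylic acid or a longer chain in place of the ring. Also open, on these data alone, is whether cyclohex-1-en-1-yl gives the same result with 2-fluorophenyl on the aromatic nitrogen.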